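This account rests on a few compounds, and the source may have more. Where it says the series, first, only, none or still open, it means among the compounds named here.

In a functional assay on A549 cells (Homo sapiens) for antiproliferative activity, read by MTT assay, with a stated time of 24 h (on this read-out lower numbers stand for stronger inhibition and higher numbers for weaker inhibition), the measured compounds are:
- compound 1 `FC(F)(F)c1ccc(-c2nn(-c3ccccc3)cc2-c2nc3ccccc3[nH]2)cc1` gives 3620 nM
- compound 2 `COc1ccc(S(=O)(=O)n2c(-c3cn(-c4ccccc4)nc3-c3ccc(F)cc3)nc3ccccc32)cc1` gives 350 nM
- compound 3 `O=S(=O)(c1ccccc1)n1c(-c2cn(-c3ccccc3)nc2-c2ccc(C(F)(F)F)cc2)nc2ccccc21` gives 480 nM

Compound 3 at 480 nM lies within the scatter of compound 2 and, together with it, well under compound 1 at 3620 nM on this scale. Compound 4 `COc1ccc(S(=O)(=O)n2c(-c3cn(-c4ccccc4)nc3-c3ccc(C(F)(F)F)cc3)nc3ccccc32)cc1` has not yet been measured. It differs from compound 3 by methoxy in place of hydrogen on an aromatic carbon, para to a large group, so that phenylsulfonyl becomes (4-methoxyphenyl)sulfonyl (methoxy in place of hydrogen on an aromatic carbon). Within the data shown here, the one measured step (a 7.5-fold lower number from compound 1 to compound 3 (0.88 log units; beyond the scatter)) was phenylsulfonyl in place of hydrogen on an aromatic nitrogen. It touches the same group but not the methoxy, so it sets no size for this change. Compound 2 carries (4-methoxyphenyl)sulfonyl on a structure that differs elsewhere, and compound 2 at 350 nM stays within the scatter of compound 3, so no shift beyond the scatter is expected. The expected step is small (a 1.2-fold lower number from compound 3 to compound 4 (0.08 log units; within the scatter)) and without a firm direction. Compound 4 is estimated at 400 nM with an expected range of 170 nM to 950 nM for this measurement.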

Compound 4, half-maximal inhibitory concentration: 170 nM
Compound 4: middle estimate off by 2.4-fold (0.37 log units), on the high side, and the stated range covers the measured number.
By their numbers in this assay, from the lowest: compound 4; then compounds 2 and 3 (each within the scatter of the next); then compound 1.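

Going from phenylsulfonyl to (4-methoxyphenyl)sulfonyl in this assay gives a 2.8-fold lower number from compound 3 to compound 4 (0.45 log units; beyond the scatter) and shows that this position, para to a large group, responds to methoxy in place of hydrogen beyond the scatter. Trifluoromethyl in place of fluoro on an aromatic carbon, with the (4-methoxyphenyl)sulfonyl group held constant, gives a 2.1-fold lower number from compound 2 to compound 4 (0.31 log units; beyond the scatter) and so shows, at a small margin, that this second site also counts. Placing (4-methoxyphenyl)sulfonyl on the aromatic nitrogen gives a 21-fold lower number from compound 1 to compound 4 (1.33 log units; beyond the scatter) and this exceeds a 7.5-fold lower number from compound 1 to compound 3 (0.88 log units; beyond the scatter) seen with phenylsulfonyl.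

The compounds shown leave open whether a hydroxyl, an ethoxy or an amine at this position would lower the number further, and whether methoxy acts the same way when fluoro replaces trifluoromethyl. No data at hand bear on what lies behind these steps.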